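The compounds below may be only part of what the source reports. "The series", "measured", "known", "first", "only" and "open" are said of these compounds alone.

Measured in a functional assay on HL-60 cells (Homo sapiens) for inhibition, read by MTT assay, with a stated time of 72 h; on this read-out lower numbers stand for stronger inhibition and higher numbers for weaker inhibition:
- compound 1 `Cc1nc(-c2ccccc2)c(C(=O)N2CCN(c3cccc(Cl)c3)CC2)o1`: 39.2 nM
- compound 2 `COc1ccc(-c2nc(C)oc2C(=O)N2CCN(c3cccc(Cl)c3)CC2)cc1OC`: "not active" (no number reported)

Compound 2 has no number and is reported only as "not active" (no number reported), so its gap to the other measured compound has no size. Compound 3 `Cc1nc(-c2ccc(F)cc2)c(C(=O)N2CCN(c3cccc(Cl)c3)CC2)o1` is not yet measured. The change is 4-fluorophenyl in place of 3,4-dimethoxyphenyl on an aromatic carbon. In this assay the expected direction is toward stronger inhibition, with no size that can be stated. Among the compounds with values here, the only support is compound 1 at 39.2 nM, a single active member of the series. Compound 3 is expected at about 50 nM, with an estimated range of 12 nM to 300 nM.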

Compound 3, half-maximal inhibitory concentration: 40.1 nM
Estimate against measurement, compound 3: 1.2-fold (0.10 log units) above, within the range that was stated.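

In this assay, fluoro in place of hydrogen on the phenyl group gives a 1.0-fold higher number from compound 1 to compound 3 (0.01 log units; within the scatter), so 4-fluorophenyl and phenyl read alike at this place on the shared core. Compound 2, with 3,4-dimethoxyphenyl at the same place, is reported only as not active, so its step to compound 3 cannot be read. No measurement shown explains that contrast.

The compounds shown leave open whether a single methoxy group on the phenyl ring is enough to give the not-active result of compound 2. They also leave open how an amine or a carboxylic acid on that ring would read.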